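The source may report more compounds than this note shows. Statements on the series, on what has been measured and on what is new or still open speak of the compounds shown alone.

Of the compounds shown here, three have been measured in a functional assay on HeLa cells (Homo sapiens) for antiproliferative activity, read by sulforhodamine B assay, with a stated time of 48 h; on this read-out lower numbers stand for stronger inhibition of growth and higher numbers for weaker inhibition of growth. Compound 1 (`Sc1nnc(C2=C(Cl)c3ccccc3CCC2)n1-c1ccccc1`) gives 5500 nM, compound 2 (`Cc1cc2c(cc1C)C(Cl)=C(c1nnc(Nc3ccccc3)s1)CCC2`) gives 4920 nM, and compound 3 (`ClC1=C(c2nnc(-c3ccccc3)o2)CCCc2ccccc21`) gives 3220 nM. Compound 3 therefore stands within the usual scatter of both other compounds, and the three cannot be ranked. Compound 4 (`Cc1ccc(-c2nnc(C3=C(Cl)c4ccccc4CCC3)o2)cc1`) differs from compound 3 by a methyl in place of hydrogen on an aromatic carbon, para to a large group: methyl in place of hydrogen on an aromatic carbon. Going by the values given here, no measured pair shows the effect of such a change, so no step beyond the scatter is expected in this assay, in either direction. The expected step is a 1.1-fold lower number from compound 3 to compound 4 (0.03 log units; within the scatter). Compound 4 is expected at 3000 nM, with an estimated range of 1300 nM to 7000 nM.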

Compound 4, concentration for 50% growth inhibition: 79 nM
For compound 4 the middle estimate is 38-fold (1.58 log units) above the measured one; measured number outside the range, below it.
By their numbers in this assay, from the lowest: compound 4; then compounds 3, 2 and 1 (each within the scatter of the next).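

In this assay, the change from phenyl to 4-methylphenyl gives a 41-fold lower number from compound 3 to compound 4 (1.61 log units; beyond the scatter). Going by these compounds alone, a single added methyl at this place, para to a large group, thus moves the number far beyond the scatter, which the earlier compounds, all within the scatter of one another, gave no sign of. No available evidence accounts for the size of this step.

The compounds shown leave open whether methyl is special here, or whether an ethyl, a methoxy or a chlorine at the same place would do the same. They also leave open whether the gain would carry over to the cores of compound 1 and compound 2.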